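A few compounds are considered here, and "the series" means these few. Any claim that something is new, unique, unknown or untested is made for them only; others in the source may bear on it.

Compound 1 `CCc1cc(-c2noc(-c3cc(C)nc(CN(C)CC(C)C)c3)n2)cc(C)c1OC[C@@H](O)CNC(=O)CO` and compound 2 `CCc1cc(-c2noc(-c3cc(C)cc(CN(C)C)c3)n2)cc(C)c1OC[C@@H](O)CNC(=O)CO` share a core and differ only in the amine-bearing ring. In an ADME assay on liver (strain Wistar) for metabolic stability, with Liver microsome (Rattus norvegicus) as the target, read by LC-MS, using microsomes and NADPH, with a stated time of 15 min, tested at 1 uM (on this read-out higher numbers stand for fast clearance and lower numbers for slow clearance), compound 1 gives 1090 mL.min-1.g-1. Compound 2 reaches only a limit of this assay, > 4800 mL.min-1.g-1 (the limit of > 4800 mL.min-1.g-1 in this assay, at which 1 of the 2 values shown sits), so its true clearance is not known as a number. Compound 3 `CCc1cc(-c2noc(-c3cc(C)cc(CN(C)CC)c3)n2)cc(C)c1OC[C@@H](O)CNC(=O)CO` differs from compound 2 by methyl in place of hydrogen on a saturated chain carbon bound to an amine nitrogen. The step of an at least 1.0-fold lower number from compound 2 to compound 3 (0.02 log units; that floor lies within the scatter) is expected to stay within the scatter. Compound 3 is therefore estimated at 4500 mL.min-1.g-1, between 1800 mL.min-1.g-1 and 9000 mL.min-1.g-1.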

Compound 3, intrinsic clearance in microsomes: > 5000 mL.min-1.g-1
Compound 3 gave a limit, no number; the forecaster's own chance of this, stated with the estimate: 50%; at least 1.1-fold (0.04 log units) between middle value and limit.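

Within the data shown here, compound 2 and compound 3 both give only limits and no numbers, so no step between them can be read. The compounds shown leave open how fast either is truly cleared, and whether methyl in place of hydrogen on this chain carbon changes clearance at all.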